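The compounds below may be only part of what the source reports. "The series", "measured", "known", "first", "only" and "open" are said of these compounds alone.

Measured in a functional assay on CWR22R cells (Homo sapiens) for antiproliferative activity, read by propidium iodide staining, with a stated time of 96 h; on this read-out lower numbers stand for stronger inhibition and higher numbers for weaker inhibition:
- compound 1 `CC(O)(CSc1cccc(S(F)(F)(F)(F)F)c1)C(=O)Nc1ccc(C#N)c(C(F)(F)F)c1`: 20400 nM
- compound 2 `CC(O)(CSc1cccc(S(F)(F)(F)(F)F)c1)C(=O)Nc1ccc([N+](=O)[O-])c(C(F)(F)F)c1`: 8800 nM
- compound 3 `CC(O)(CSc1cccc(S(F)(F)(F)(F)F)c1)C(=O)Nc1ccc(S(F)(F)(F)(F)F)cc1`: 17700 nM

Compound 3 lies within the scatter of both compound 1 and compound 2, so it cannot be separated from either. Compound 4 `CC(O)(CSc1cccc(OC(F)(F)F)c1)C(=O)Nc1ccc(S(F)(F)(F)(F)F)cc1` differs from compound 3 as follows: a group of 5 heavy atoms (1 carbon, 1 oxygen, 3 fluorine; no ring) in place of a group of 6 heavy atoms (5 fluorine, 1 sulfur; no ring), on an aromatic carbon. The trifluoromethoxy group enters on an aromatic carbon of a six-membered aromatic ring of carbon only, meta to a large group.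

Among the measured compounds shown here, the only measured step is a 2.3-fold lower number from compound 1 to compound 2 (0.37 log units; beyond the scatter). It is modest and swaps nitro for cyano, not the group that leaves here, so it offers only a rough guide to size. No shift beyond the scatter is therefore expected in this assay. The estimated step is a 1.2-fold lower number from compound 3 to compound 4 (0.07 log units; within the scatter). For compound 4 the expected value is 15000 nM, with an estimated range of 6500 nM to 33000 nM.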

Compound 4, half-maximal inhibitory concentration: 14000 nM
Compound 4: middle estimate off by 1.1-fold (0.03 log units), on the high side, within the range that was stated.
By their numbers in this assay, from the lowest: compounds 2, 4, 3 and 1 (each within the scatter of the next, the first and the last beyond it).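

At this aromatic carbon, meta to a large group, trifluoromethoxy in place of the group of 6 heavy atoms gives a 1.3-fold lower number from compound 3 to compound 4 (0.10 log units; within the scatter) in this assay. Among the compounds shown here, compounds 1, 2 and 3 all carry the same group here, so this is the first reading of this place, and the exchange leaves the number within the scatter. No measured evidence bears on why these two groups read alike.

On these data alone, whether an amine or a carboxylic acid at this carbon would move the number beyond the scatter remains open. Also open, as far as these compounds go, is whether trifluoromethoxy here would read the same alongside the nitro-bearing ring of compound 2.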